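This account rests on a few compounds, and the source may have more. Where it says the series, first, only, none or still open, it means among the compounds named here.

Among the measured compounds shown here, compound 1 `COc1cc(-c2nn(-c3cccc(NC(=O)Nc4ccc(Cl)c(Cl)c4)c3)cc2-c2ccncc2)ccc1Cl` is one of three compounds measured in a functional assay on UO-31 cells (Homo sapiens) for inhibition, read by sulforhodamine B assay, with a stated time of 48 h; a higher number here means a weaker inhibitor of growth, a lower number a stronger inhibitor of growth. In this assay compound 1 gives 845 nM, the second highest of the three numbers. Compound 2 `O=C(Nc1cccc(-n2cc(-c3ccncc3)c(-c3ccc(Cl)c(O)c3)n2)c1)Nc1ccc(Cl)c(Cl)c1` differs from it only in having hydrogen in place of methyl on an oxygen on an aromatic ring; compound 2 gives 1250 nM, and the step of a 1.5-fold higher number from compound 1 to compound 2 (0.17 log units; within the scatter) lies within the scatter. Compound 3 `O=C(Nc1cccc(-n2cc(-c3ccncc3)c(-c3ccc(Cl)c(O)c3)n2)c1)Nc1cc(C(F)(F)F)cc(C(F)(F)F)c1` carries the same hydroxyl-bearing core as compound 2 but a different aryl group on the urea. In this assay compound 3 gives 647 nM.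

Compound 4 `COc1cc(-c2nn(-c3cccc(NC(=O)Nc4ccc(Cl)c(C(F)(F)F)c4)c3)cc2-c2ccncc2)ccc1Cl` is not yet measured. It differs from compound 1 by trifluoromethyl in place of chloro on an aromatic carbon. For the measured compounds named here, no measured step changes this group directly. Going by the values given here, the only pair in which the urea aryl changes is compound 2 and compound 3: compound 2 gives 1250 nM and compound 3 gives 647 nM, a difference that the scatter of the assay largely covers. Compound 1 and compound 3 are also within the scatter of each other. The three measured numbers sit close together, so the expectation for compound 4 is a number near that of compound 1, with no step beyond the scatter, and the expected step is a 1.2-fold lower number from compound 1 to compound 4 (0.08 log units; within the scatter). Compound 4 is therefore estimated at 700 nM, with a range from 350 nM to 1400 nM.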

Compound 4, concentration for 50% growth inhibition: 865 nM
Beside the measured number, compound 4's estimate is 1.2-fold (0.09 log units) below it; low and high end bracket the measured number.
By their numbers in this assay, from the lowest: compounds 3, 1, 4 and 2 (each within the scatter of the next).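

Among the compounds shown here, compound 4 gives the first direct reading of the change from 3,4-dichlorophenyl to 4-chloro-3-(trifluoromethyl)phenyl with the rest of compound 1 held fixed: in this assay the change gives a 1.0-fold higher number from compound 1 to compound 4 (0.01 log units; within the scatter) and so cannot be told apart from no change at all. At this aromatic carbon, ortho to a chloro group and meta to a large group, a trifluoromethyl group of 4 heavy atoms therefore stands in for a chloro group of 1 heavy atom with no step beyond the scatter, a statement that rests on this single pair. No measurement offered here bears on why the two compounds read alike.

From the compounds shown here alone, whether the same replacement would read the same on the hydroxyl-bearing core of compound 2 remains open, since only the core of compound 1 carries it here. Going by these compounds, it is equally open whether a different group at this aromatic carbon, such as an amine, a nitrile or a carboxylic acid, would move the number beyond the scatter in this assay or leave it where these compounds sit.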